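Swapping allyloxy for methyl on a carbonyl carbon

The source may report more compounds than this note shows. Statements on the series, on what has been measured and on what is new or still open speak of the compounds shown alone.

Compound 1 `C=CCOC(=O)SCCCCCCNC(=O)c1cc(-c2ccncc2)n[nH]1` gives 12600 nM in growth inhibition
Compound 2 `Cc1cc(C(=O)NCCCCCCS)[nH]n1` gives > 50000 nM, a limit of the assay and not a number

Within the data shown here, in a functional assay on MCF7 cells (Homo sapiens) for inhibition, read by MTT assay, with a stated time of 96 h (a higher number here means a weaker inhibitor of growth, a lower number a stronger inhibitor of growth), compound 1 gives 12600 nM, the only true number so far. Compound 2 gives > 50000 nM, which is a limit. Compound 1 therefore has no measured neighbour to be ranked against.

Compound 3 (`CC(=O)SCCCCCCNC(=O)c1cc(-c2ccncc2)n[nH]1`) differs from compound 1 in one place, with methyl in place of allyloxy on a carbonyl carbon. Among the measured compounds shown here, no measured pair yet shows what this swap does, so little change beyond the scatter is expected in this assay, with a slight lean towards stronger growth inhibition. The expected move is a 1.4-fold lower number from compound 1 to compound 3 (0.15 log units; within the scatter), a modest one. Compound 3 is estimated at 9000 nM, with a likely range from 3000 nM to 30000 nM.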

Compound 3, concentration for 50% growth inhibition: 24900 nM
Compound 3: middle estimate off by 2.8-fold (0.44 log units), on the low side, and the stated range covers the measured number.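

Swapping allyloxy for methyl on a carbonyl carbon whose other neighbour is sulfur gives, in this assay, a 2.0-fold higher number from compound 1 to compound 3 (0.30 log units; within the scatter). Among these compounds, this is the first measured pair at this position, and the two compounds cannot be told apart, even though the group that leaves has 4 heavy atoms and a double bond while the one that enters has 1 heavy atom. Growth inhibition at this level therefore does not rely on the allyloxy group, and nothing measured here says why the two compounds read alike.

Still open, going by these compounds, is whether an amine or a phenyl ring on this carbonyl carbon would give a number clearly apart from those of this pair. Also open, on these data alone, is what a longer chain in place of the hexyl-length linker would do.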